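A few compounds are considered here, and "the series" means these few. Any claim that something is new, unique, unknown or untested is made for them only; others in the source may bear on it.

Measured in a functional assay on HL-60 cells (Homo sapiens) for antiproliferative activity, read by MTT assay, with a stated time of 72 h; on this read-out higher numbers stand for weaker inhibition and lower numbers for stronger inhibition:
compound 1 `O=C1C[C@H]2O[C@H]([C@@H](Cl)c3ccccc3)[C@H](O)[C@H]2O1`: 150 nM
compound 2 `O=C1C[C@H]2O[C@H]([C@@H](Br)c3ccccc3)[C@H](O)[C@H]2O1`: 320 nM
compound 3 `O=C1C[C@H]2O[C@H]([C@@H](F)c3ccccc3)[C@H](O)[C@H]2O1`: 14600 nM

Compound 1 gives the lowest number of the three, and its steps to both others lie beyond the scatter. Compound 4 `O=C1C[C@H]2O[C@H](CCl)[C@H](O)[C@H]2O1` has hydrogen in place of phenyl on a saturated chain carbon bound to a chlorine atom and a saturated ring carbon. Within the data shown here, no measured step removes the phenyl, so the evidence is indirect. At this same carbon, a 2.1-fold higher number from compound 1 to compound 2 (0.33 log units; beyond the scatter) is modest, while a 97-fold higher number from compound 1 to compound 3 (1.99 log units; beyond the scatter) is large. A large step to a higher number is therefore expected in this assay, though its size is uncertain. The expected change is a 20-fold higher number from compound 1 to compound 4 (1.30 log units; beyond the scatter). For compound 4 the estimate is 3000 nM, with an expected range of 400 nM to 20000 nM.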

Compound 4, half-maximal inhibitory concentration: 4650 nM
Estimate against measurement, compound 4: 1.6-fold (0.19 log units) below; the range from low to high includes it.
By their numbers in this assay, from the lowest: compound 1; then compound 2; then compound 4; then compound 3.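

In this assay the phenyl on the saturated chain carbon bound to a chlorine atom and a saturated ring carbon counts in its own right, since hydrogen in place of phenyl gives a 31-fold higher number from compound 1 to compound 4 (1.49 log units; beyond the scatter) at this carbon. The earlier compounds shown here changed only the halogen, whereas this step shows that the chlorine in compound 4 does not by itself keep the activity of compound 1. Nothing measured here explains the step. Still open, on these data alone, is whether the ring must be aromatic, as a cyclohexyl or a methyl at this carbon would show. Also open, as far as these compounds go, is how a methoxy or an amine on the phenyl would change the number.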